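A few compounds are considered here, and "the series" means these few. Any claim that something is new, unique, unknown or untested is made for them only; others in the source may bear on it.

Values in a functional assay on B16-F10 cells (Mus musculus) for antiproliferative activity, read by CCK-8 assay, with a stated time of 48 h; a higher number here means a weaker inhibitor, a lower number a stronger inhibitor:

compound 1 `COc1ccc(/C=C\c2cc(OC)c(OC)c(OC)c2)cc1OCc1ccc(CN[C@H](C(=O)O)[C@H](C)O)cc1`: a limit, > 10000 nM
compound 2 `COc1ccc(/C=C\c2cc(OC)c(OC)c(OC)c2)cc1OCc1ccc(CNCCO)cc1`: 6600 nM
compound 3 `COc1ccc(/C=C\c2cc(OC)c(OC)c(OC)c2)cc1OCc1ccc(CN2CCCCC2C(=O)NCCNC(=O)OC(C)(C)C)cc1`: 4700 nM

Compound 1 sits at the limit of > 10000 nM in this assay, at which 1 of the 3 values shown sits, so only an upper bound is known for it; compound 2 and compound 3 give numbers. Compound 4 `COc1ccc(/C=C\c2cc(OC)c(OC)c(OC)c2)cc1OCc1ccc(CN2CC[C@@H](O)C2)cc1` is not yet measured in this assay.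

Change from compound 1 to compound 4: 3-hydroxypyrrolidin-1-yl in place of (1-carboxy-2-hydroxypropyl)amino on a saturated chain carbon bound to an aromatic carbon.

Among the compounds with values here, the one measured step on this nitrogen, an at least 1.5-fold lower number from compound 1 to compound 2 (0.18 log units; that floor lies within the scatter), swapped the same leaving group for a small hydroxyalkyl and moved the number off the limit. Compound 4 makes a swap of that kind, to a ring carrying one hydroxyl, and a step of similar size and direction is expected, an at least 1.8-fold lower number from compound 1 to compound 4 (0.25 log units; that floor lies within the scatter), though it may again only reach the limit. Compound 4 is estimated at 5500 nM, expected between 2500 nM and 12000 nM.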

Compound 4, half-maximal inhibitory concentration: > 10000 nM
Compound 4: a limit, no number (the forecaster's own chance of this, stated with the estimate: 30%); at least 1.8-fold (0.25 log units) between middle value and limit.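

In this assay compound 4 gives > 10000 nM, which is a limit and not a number. Moving from the open (2-hydroxyethyl)amino to the closed 3-hydroxypyrrolidin-1-yl gives an at least 1.5-fold higher number from compound 2 to compound 4 (0.18 log units; that floor lies within the scatter), so a hydroxyl-bearing amine on this carbon does not by itself bring a measurable number, and ring and chain are not yet separated. The step between the two compounds at the limit cannot be read: the limit of > 10000 nM in this assay, at which 2 of the 4 values shown sit.

As far as these compounds go, whether 3-hydroxypyrrolidin-1-yl truly differs from (2-hydroxyethyl)amino stays open. So does how a morpholine ring or a longer hydroxyalkyl chain on this carbon would read.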